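Compound 3 to compound 4: starting from a limit

The source may hold more compounds than are shown below. What is called first, only, known or untested is meant among the compounds shown, and "the series" means these compounds.

In a functional assay on MCF cells (Homo sapiens) for antiproliferative activity, with a stated time of 72 h (a lower number here means a stronger inhibitor, a higher number a weaker inhibitor), compound 1 `OC[C@H]1O[C@@H](n2cnc3c(NCc4cccc(F)c4)ncnc32)[C@H](O)[C@@H]1O` gives a measured number, 15300 nM. Compound 2 `OC[C@H]1O[C@@H](n2cnc3c(NCc4ccc(Br)cc4)ncnc32)[C@H](O)[C@@H]1O` gives > 166000 nM, which is a limit. Compound 3 `OC[C@H]1O[C@@H](n2cnc3c(NCc4c(F)ccc(F)c4F)ncnc32)[C@H](O)[C@@H]1O` gives > 166000 nM, also a limit. Compound 3 therefore stands at the limit of > 166000 nM in this assay, at which 2 of the 3 values shown sit.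

The next change places 2-(difluoromethoxy)phenyl in place of 2,3,6-trifluorophenyl on a saturated chain carbon bound to a nitrogen on an aromatic ring, giving compound 4 `OC[C@H]1O[C@@H](n2cnc3c(NCc4ccccc4OC(F)F)ncnc32)[C@H](O)[C@@H]1O`: 2-(difluoromethoxy)phenyl in place of 2,3,6-trifluorophenyl on a saturated chain carbon bound to a nitrogen on an aromatic ring.

Compound 4 also lacks the 3-fluorophenyl of compound 1, so the measured steps that bear on it are an at least 10-fold higher number from compound 1 to compound 2 (1.03 log units; beyond the scatter) and an at least 10-fold higher number from compound 1 to compound 3 (1.03 log units; beyond the scatter), both large. On those steps, compound 4 is expected to remain a weak inhibitor in this assay, with a reading that may again be only a limit. The expected step is small, towards a slightly lower number at most: an at least 1.8-fold lower number from compound 3 to compound 4 (0.26 log units; that floor lies within the scatter). For compound 4 the estimated value is 90000 nM, with an expected range of 20000 nM to 200000 nM.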

Compound 4, half-maximal inhibitory concentration: > 166000 nM
Compound 4: only a limit was reported; the forecaster's own chance of this, stated with the estimate: 60%; middle value at least 1.8-fold (0.26 log units) from the limit.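

In this assay compound 4 gives > 166000 nM, which is a limit. Even with an entering group that carries an oxygen and a hydrogen-bond acceptor, unlike the groups before it, the change on the saturated chain carbon bound to a nitrogen on an aromatic ring gives an at least 10-fold higher number from compound 1 to compound 4 (1.03 log units; beyond the scatter). The steps among compound 2, compound 3 and compound 4 join limit to limit and cannot be read, and the series now gathers at one reading: the limit of > 166000 nM in this assay, at which 3 of the 4 values shown sit.

Among the compounds shown, only compound 1, with its 3-fluorophenyl, gives a measured number, 15300 nM, so it remains open what in that group separates it from the other three. The compounds shown also leave open how unsubstituted phenyl, or a phenyl bearing an amine or a carboxylic acid, would read in this assay.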